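The source may report more compounds than this note shows. Statements on the series, on what has been measured and on what is new or still open speak of the compounds shown alone.

Measured so far:
- compound 1, `C=C1C(=O)O[C@@H]2CC(C)=C([C@@H](C)CCCOC(C)=O)[C@@H](OC(=O)CN(CC)CC)[C@H]12`: 13100 nM
- compound 2, `C=C1C(=O)O[C@@H]2CC(C)=C([C@@H](C)CCCOC(C)=O)[C@@H](OC(=O)COc3ccc(C(=O)OCCC)cc3)[C@H]12`: 37500 nM

In a functional assay on HCT-116 cells (Homo sapiens) for cytotoxicity, read by sulforhodamine B assay, with a stated time of 72 h (a lower number here means a stronger inhibitor, a higher number a weaker inhibitor), compound 1 holds the lower of the two numbers, and compound 2 gives 37500 nM, a gap beyond the usual scatter. Among the compounds with values here, no single-point step between two measured compounds is available, so any expectation for a new ester rests on these two values alone.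

Compound 3, `C=C1C(=O)O[C@@H]2CC(C)=C([C@@H](C)CCCOC(C)=O)[C@@H](OC(=O)COc3cccc4[nH]nnc34)[C@H]12`, departs from compound 1 by one change: a group of 10 heavy atoms (6 carbon, 3 nitrogen, 1 oxygen; one five-membered aromatic ring with 3 hetero atoms, one six-membered aromatic ring of carbon only) in place of a group of 5 heavy atoms (4 carbon, 1 nitrogen; no ring), on a saturated chain carbon bound to a carbonyl carbon

For compound 3 the step from compound 1 is expected to be modest and towards a higher number, a 1.9-fold higher number from compound 1 to compound 3 (0.28 log units; within the scatter), because compound 2 gives 37500 nM and is the only other variant of this ester here. Compound 3 is estimated at 25000 nM, within a range of 8000 nM to 80000 nM. The range is wide; with only two anchors no closer call is justified.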

Compound 3, half-maximal inhibitory concentration: 23700 nM
The estimate for compound 3 lay 1.1-fold (0.02 log units) above the measured number; the range from low to high includes it.
By their numbers in this assay, from the lowest: compounds 1, 3 and 2 (each within the scatter of the next, the first and the last beyond it).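

In this assay, a group with two aromatic rings, one five-membered with 3 hetero atoms and one six-membered of carbon only, can take the place of diethylamino on the saturated chain carbon bound to a carbonyl carbon with only a 1.8-fold higher number from compound 1 to compound 3 (0.26 log units; within the scatter). Against the other ring-bearing ester, the step is a 1.6-fold lower number from compound 2 to compound 3 (0.20 log units; within the scatter), so these two aromatic groups are not separated by this read-out, and compound 3 cannot be told apart from either neighbour. No measurement at hand bears on what lies behind these steps.

From the compounds shown here alone, whether a carboxylic acid, a primary amine or a longer chain at this place would give a step beyond the scatter from compound 1 remains open. Going by these compounds, the core and the acetate ester are the same in all three compounds, so their contribution also remains open.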